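This account rests on a few compounds, and the source may have more. Where it says the series, first, only, none or still open, it means among the compounds named here.

Values in an ADME assay on MT4 cells (Homo sapiens) for cytotoxicity, with a stated time of 5 days (on this read-out higher numbers stand for lower toxicity in this test and lower numbers for higher toxicity in this test), are as follows.

Compound 1 `CC(C)(C)C#Cc1cc(N(C(=O)[C@H]2CC[C@H](C)CC2)[C@H]2CC[C@H](OC3CCOCC3)CC2)c(C(=O)O)s1` gives > 20000 nM as a limit
Compound 2 `CC(C)(C)C#Cc1cc(N(C(=O)[C@H]2CC[C@H](C)CC2)[C@H]2CC[C@H](OC3CCOC3)CC2)c(C(=O)O)s1` gives > 20000 nM as a limit
Compound 3 `CC(C)(C)C#Cc1cc(N(CCO)C(=O)[C@H]2CC[C@H](C)CC2)c(C(=O)O)s1` gives > 20000 nM as a limit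

In this assay compound 3 stands at > 20000 nM and that is a limit, not a number. Among the measured compounds shown here, the data offer the limit of > 20000 nM in this assay, at which 3 of the 3 values shown sit, and no ranking of the compounds.

The change to compound 4 `CC(C)(C)C#Cc1cc(N(C(=O)[C@H]2CC[C@H](C)CC2)[C@H]2CC[C@H](O)CC2)c(C(=O)O)s1` puts 4-hydroxycyclohexyl in place of 2-hydroxyethyl on an amide-type nitrogen, counted as 4-hydroxycyclohexyl in place of 2-hydroxyethyl on an amide-type nitrogen and leaving the rest of the structure as it is.

For the measured compounds named here, two measured steps bear on this change, and neither has a readable size. The nearer is a step that the two limits leave unreadable from compound 2 to compound 3 and it put 2-hydroxyethyl in place of 4-((oxolan-3-yl)oxy)cyclohexyl on that same nitrogen. Both compounds of that step sit at the limit, so a substituted cyclohexyl on this nitrogen has not brought a number into view. The other is a step that the two limits leave unreadable from compound 1 to compound 2 and it changed only the oxygen-linked ring.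

No step beyond the scatter is therefore expected in this assay, in either direction. The expected step is a number no higher from compound 3 to compound 4 (the limit leaves the size open) and it is estimated to be no real change. For compound 4 the estimate is 20000 nM with an expected range from 12000 nM to 50000 nM in this read-out.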

Compound 4, half-maximal cytotoxic concentration: > 20000 nM
Compound 4 was reported as a limit; the forecaster's own chance of this, stated with the estimate: 85%; the middle value sits exactly at the limit.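

In this assay compound 4 gives > 20000 nM, which is a limit. Its steps from compound 1, compound 2 and compound 3 therefore cannot be read, and the compounds stay unranked: the limit of > 20000 nM in this assay, at which 4 of the 4 values shown sit.

The compounds shown leave open where any of the four would give an actual number in this assay, and whether the group on the amide-type nitrogen matters there.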